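A 2-chlorophenyl swap on the sulfonyl sulfur

The source may report more compounds than this note shows. Statements on the series, on what has been measured and on what is new or still open speak of the compounds shown alone.

In an ADME assay on HEK293 cells (Homo sapiens) for cytotoxicity, read by resazurin assay, with a stated time of 48 h (a lower number here means that less compound is tolerated, a higher number that more compound is tolerated), compound 1 (`Cc1ccc(S(=O)(=O)Nc2ccc(-c3nc4ccccc4o3)cc2)cc1`) gives 88000 nM as its half-maximal cytotoxic concentration. In this assay compound 2 (`O=S(=O)(Nc1ccc(-c2nc3ccccc3o2)cc1)c1ccc(Cl)s1`) stands at > 100000 nM as a limit of the assay and not a number. Compound 3 (`O=S(=O)(Nc1ccc(-c2nc3ccccc3o2)cc1)c1ccccc1Cl`) differs from compound 2 by one change (2-chlorophenyl in place of 5-chlorothiophen-2-yl on a sulfonyl sulfur) on a sulfonyl sulfur: 2-chlorophenyl in place of 5-chlorothiophen-2-yl. Among the compounds with values here, the one measured step at that place is an at least 1.1-fold higher number from compound 1 to compound 2 (0.05 log units; that floor lies within the scatter) and on that ground no step beyond the scatter is expected in this assay for this change. The expected step is an at least 1.0-fold lower number from compound 2 to compound 3 (0.02 log units; that floor lies within the scatter) as estimated here. Compound 3 is expected at 95000 nM with 50000 nM to 180000 nM as the estimated range.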

Compound 3, half-maximal cytotoxic concentration: > 100000 nM
Compound 3: only a limit was reported (the forecaster's own chance of this, stated with the estimate: 45%); middle value at least 1.0-fold (0.02 log units) away from the limit.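

With 2-chlorophenyl on the sulfonyl sulfur, compound 3 reaches the same limit as compound 2, so in this assay that limit is not confined to the five-membered aromatic ring with its hetero atom. Against 4-methylphenyl, the reading is an at least 1.1-fold higher number from compound 1 to compound 3 (0.05 log units; that floor lies within the scatter). The step between compound 2 and compound 3 cannot be read because both values are limits and not numbers: the limit of > 100000 nM in this assay, at which 2 of the 3 values shown sit.

As far as these compounds go, how far compound 2 and compound 3 lie past that limit remains open. So does whether an amine or a carboxylic acid on the sulfonyl sulfur would give a readable number.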